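A few compounds are considered here, and "the series" means these few. Any claim that something is new, unique, unknown or untested is made for them only; others in the source may bear on it.

Working notes on the series

The core of compound 1 `O=C(Nc1ccccc1)O/N=C1\N[C@H](CO)[C@@H](O)[C@H](O)[C@H]1O` carries an aromatic group on the amide-type nitrogen. In an assay on isolated protein for inhibition of alpha-galactosidase (Coffea arabica) (a higher number here means a weaker inhibitor, a lower number a stronger inhibitor), compound 1 gives only a limit of the assay, > 100000 nM. Compound 2 `CSc1ccc(NC(=O)O/N=C2\N[C@H](CO)[C@@H](O)[C@H](O)[C@H]2O)cc1` carries methylsulfanyl in place of hydrogen on an aromatic carbon. In this assay compound 2 likewise gives only a limit, > 100000 nM. Within the data shown here, the single measured step is a step that the two limits leave unreadable from compound 1 to compound 2, and compound 2 stands at the limit of > 100000 nM in this assay, at which 2 of the 2 values shown sit, so no number is available for it, only the limit.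

Compound 3 `O=C(Nc1cccs1)O/N=C1\N[C@H](CO)[C@@H](O)[C@H](O)[C@H]1O` differs from compound 2 by thiophen-2-yl in place of 4-(methylsulfanyl)phenyl on an amide-type nitrogen. Among the measured compounds shown here, the one measured step bears on this change only loosely, as another exchange of the aromatic group on the same amide-type nitrogen, and its size cannot be read because both ends sit at the limit. For the measured compounds named here, no compound has so far reached a readable number in this assay. Compound 3 is therefore expected to remain at the limit as well, with an expected step that the limit leaves unreadable from compound 2 to compound 3. The estimate for compound 3 is 200000 nM, in a range from 100000 nM to 1000000 nM, and most likely only a limit will again be reported.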

Compound 3, half-maximal inhibitory concentration: > 100000 nM
Compound 3 gave a limit, no number; the forecaster's own chance of this, stated with the estimate: 85%; the middle value lies beyond the limit too.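

No step among compound 1, compound 2 and compound 3 can be read in this assay, since all three sit at the same limit: the limit of > 100000 nM in this assay, at which 3 of the 3 values shown sit.

The compounds shown leave open whether any aromatic group on the amide-type nitrogen of the shared core gives a readable number in this assay, and how phenyl, 4-(methylsulfanyl)phenyl and thiophen-2-yl rank against one another.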